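This account rests on a few compounds, and the source may have more. Where it says the series, first, only, none or still open, it means among the compounds named here.

The measured compounds, each with its result in a functional assay on SEM cells (Homo sapiens) for cytotoxicity, with a stated time of 72 h; on this read-out higher numbers stand for an effect only at larger amounts of compound and lower numbers for an effect already at smaller amounts:

Compound 1 `C=C[C@@](C)(/C=C/c1ccc(O)cc1)CC/C=C(C)/C=C/C(=O)OCC` gives only a limit of this assay, > 36600 nM.
Compound 2 `C=C[C@@](C)(/C=C/c1ccc(O)cc1)CC/C=C(C)/C=C/C(=O)OCc1ccccc1` gives only a limit of this assay, > 36600 nM.
Compound 3 `C=C[C@@](C)(/C=C/c1ccc(O)c(/C=C/C(=O)OCC)c1)CCC=C(C)C` gives only a limit of this assay, > 36600 nM.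

None of the three compounds shows a measurable effect in this assay; all three sit at the limit of > 36600 nM in this assay, at which 3 of the 3 values shown sit. Compound 2 differs from compound 1 by phenyl in place of methyl on a saturated chain carbon bound to an oxygen next to a carbonyl group, and the step that the two limits leave unreadable from compound 1 to compound 2 is one that the two limits leave unreadable.

Compound 4 `C=C[C@@](C)(/C=C/c1ccc(O)c(/C=C/C(=O)OCc2ccccc2)c1)CCC=C(C)C` has not yet been measured in this assay. Among the measured compounds shown here, it differs from compound 3 by phenyl in place of methyl on a saturated chain carbon bound to an oxygen next to a carbonyl group, the same change as the one from compound 1 to compound 2, made at the same place. Compound 3 and compound 1 carry different cores, and the difference between the two cores is not broken down here.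

The step from compound 3 to compound 4 is expected to be as unreadable as the earlier one, a number no higher from compound 3 to compound 4 (the limit leaves the size open), because compound 3 gives only the limit > 36600 nM and the same change left compound 2 at the limit > 36600 nM. Compound 4 is therefore expected to give 36600 nM in this assay, most likely again as a limit rather than a number, with a plausible range from 15000 nM to 100000 nM.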

Compound 4, half-maximal effective concentration: > 36600 nM
Compound 4: no number, only a limit; the forecaster's own chance of this, stated with the estimate: 85%; the middle value lies on the limit itself.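

Compound 3 and compound 4 each give only a limit in this assay, so no size can be read for the step between them, and the same holds for compound 1 and compound 2. All four compounds stand at one limit: the limit of > 36600 nM in this assay, at which 4 of the 4 values shown sit.

The compounds shown leave open whether phenyl in place of methyl changes the effect at all, and at what amount any of them would act in this assay.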